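The source may hold more compounds than are shown below. What is called first, only, known or untested is meant among the compounds shown, and "the series" means these compounds.

Notes on the series sharing the core of compound 1 (`O=C(/C=C/c1ccc([N+](=O)[O-])o1)c1ccc(Br)cc1`), tested throughout in a functional assay on U-87MG ATCC cells for inhibition, with U-87 MG (Homo sapiens) as the target, read by sulforhodamine B assay, with a stated time of 72 h (a higher number here means that more compound is needed for the effect, a lower number that less compound is needed), as the only read-out. Compound 1 gives 12600 nM as the bromo member, compound 2 (`O=C(/C=C/c1ccc([N+](=O)[O-])o1)c1ccc(I)cc1`) gives 5200 nM as the iodo member, and compound 3 (`O=C(/C=C/c1ccc([N+](=O)[O-])o1)c1ccc(-n2ccnc2)cc1`) gives 13400 nM with 1H-imidazol-1-yl on the same aromatic carbon. That places the 1H-imidazol-1-yl member level with the bromo member (a 1.1-fold higher number from compound 1 to compound 3 (0.03 log units; within the scatter)) and apart from the iodo member (a 2.6-fold higher number from compound 2 to compound 3 (0.41 log units; beyond the scatter)).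

Next comes compound 4 (`O=C(/C=C/c1ccc([N+](=O)[O-])o1)c1ccc(N2CCCC2)cc1`), with pyrrolidin-1-yl in place of 1H-imidazol-1-yl on an aromatic carbon, para to a large group (pyrrolidin-1-yl in place of 1H-imidazol-1-yl on an aromatic carbon). Going by the values given here, no measured step covers this exchange. The closest evidence is the other exchanges on that aromatic carbon: the largest (a 2.6-fold higher number from compound 2 to compound 3 (0.41 log units; beyond the scatter)) is only modest, and the remaining one beyond the scatter (a 2.4-fold lower number from compound 1 to compound 2 (0.38 log units; beyond the scatter)) is of similar size. Across these three compounds the number has moved little, so no step beyond the scatter is expected, and the data fix no direction. The expected change is a 1.3-fold lower number from compound 3 to compound 4 (0.13 log units; within the scatter) as an estimate. Compound 4 is expected at 10000 nM in this assay with an estimated range of 4000 nM to 25000 nM for now.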

Compound 4, half-maximal effective concentration: 35400 nM
Beside the measured number, compound 4's estimate is 3.5-fold (0.55 log units) below it, and the stated range ends below it.
By their numbers in this assay, from the lowest: compound 2; then compounds 1 and 3 (each within the scatter of the next); then compound 4.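

In this assay, the position on an aromatic carbon, para to a large group, now separates two substituents that both have 5 heavy atoms and a five-membered ring: pyrrolidin-1-yl in place of 1H-imidazol-1-yl gives (a 2.6-fold higher number from compound 3 to compound 4 (0.42 log units; beyond the scatter)), so the number at this position is not set by substituent size as counted here. Going by these compounds alone, the earlier compounds showed only the iodo member apart from a level pair, whereas pyrrolidin-1-yl also stands apart from the bromo member (a 2.8-fold higher number from compound 1 to compound 4 (0.45 log units; beyond the scatter)) and further still from the iodo member (a 6.8-fold higher number from compound 2 to compound 4 (0.83 log units; beyond the scatter)), the widest step yet at this position and one that leaves compound 4 with the highest number of the series so far. Nothing measured here bears on the reason for this shift.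

The exchange changes both ring aromaticity and the count of ring nitrogens, so these two differences cannot be told apart from the compounds shown. Piperidin-1-yl, morpholin-4-yl or an open-chain dimethylamino group would test how far the trend extends, and none of these stands among the compounds shown.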